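Three Measured Cytotoxicities and One Expected Value

The compounds below may be only part of what the source reports. "The series", "measured", "known", "first", "only" and "open" are said of these compounds alone.

Compound 1 `Cc1ccc(-n2nc(-c3ccc(C(F)(F)F)cc3O)nc2-c2ccccc2O)cc1`: 94.1%
Compound 2 `Oc1cc(C(F)(F)F)ccc1-c1nc(-c2ccccc2O)n(-c2ccc(Br)cc2)n1`: 89.8%
Compound 3 `Oc1cc(C(F)(F)F)ccc1-c1nc(-c2ccccc2O)n(-c2ccc(I)cc2)n1`: 94.4%

In a functional assay on PC-12 cells (Rattus norvegicus) for cytotoxicity, read by MTT assay, with stated times of 2 h and 24 h, tested at 5 uM (on this read-out lower numbers stand for a weaker effect and higher numbers for a stronger effect at the one concentration tested), compound 3 gives 94.4%, the highest of the three numbers, although both gaps lie within the scatter: a number 0.3 percentage points higher from compound 1 to compound 3 (within the scatter) and a number 4.6 percentage points higher from compound 2 to compound 3 (within the scatter). Compound 4 `N#Cc1ccc(-n2nc(-c3ccc(C(F)(F)F)cc3O)nc2-c2ccccc2O)cc1` differs from compound 3 by cyano in place of iodo on an aromatic carbon. For the measured compounds named here, no measured step exchanges a halogen for a cyano group; the steps that bear on it are the exchanges on the same aromatic carbon, a number 4.3 percentage points lower from compound 1 to compound 2 (within the scatter), a number 0.3 percentage points higher from compound 1 to compound 3 (within the scatter) and a number 4.6 percentage points higher from compound 2 to compound 3 (within the scatter), all within the scatter. Compound 4 is therefore expected to show no step beyond the scatter, a number 3.4 percentage points lower from compound 3 to compound 4 (within the scatter). The estimate for compound 4 is 91%, with a range from 75% to 98%.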

Compound 4, a percentage reported as activity, at one concentration (the size of the read-out at that concentration, not a potency): 86.8%
For compound 4 the middle estimate is 4.2 percentage points above the measured one; the range from low to high includes it.
By their numbers in this assay, from the lowest: compounds 4, 2, 1 and 3 (each within the scatter of the next).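

With cyano in place of the earlier groups on this aromatic carbon, a hydrogen-bond acceptor and a triple bond enter at the position, yet this assay shows no step beyond the scatter (a number 7.6 percentage points lower from compound 3 to compound 4 (within the scatter); a number 3 percentage points lower from compound 2 to compound 4 (within the scatter); a number 7.3 percentage points lower from compound 1 to compound 4 (within the scatter)). Methyl, bromo, iodo and cyano at this place thus give numbers that cannot be told apart. Nothing measured here accounts for this result. The compounds shown leave open whether an amine, a carboxylic acid or a longer chain at this place would also stay within the scatter.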